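Replacing the Oxetane Carbamate with a Difluoropropyl Amide

A few compounds are considered here, and "the series" means these few. Any claim that something is new, unique, unknown or untested is made for them only; others in the source may bear on it.

The measured compounds:
- compound 1, `Cc1nc(S(C)(=O)=O)ccc1Oc1ncnc(OC2CCN(C(=O)OC(C)(C)C#N)CC2)c1F`, 92.9 nM
- compound 2, `Cc1nc(S(C)(=O)=O)ccc1Oc1ncnc(OC2CCN(C(=O)OC3COC3)CC2)c1F`, 326 nM
- compound 3, `Cc1nc(S(C)(=O)=O)ccc1Oc1ncnc(OC2CCN(C(=O)SC3CCC3)CC2)c1F`, 8.51 nM

Three compounds share one core and differ only in the group attached to the carbonyl on the ring nitrogen. In a functional assay on isolated protein for inhibition of Glucose-dependent insulinotropic receptor (Homo sapiens), read by HTRF and cAMP accumulation (a higher number here means that more compound is needed for the effect, a lower number that less compound is needed), compound 2 gives the highest number of the three: compound 1 sits nearest, with a 3.5-fold higher number from compound 1 to compound 2 (0.55 log units; beyond the scatter), while compound 3 is furthest away, with a 38-fold lower number from compound 2 to compound 3 (1.58 log units; beyond the scatter). Compound 1 and compound 3 themselves are separated by an 11-fold lower number from compound 1 to compound 3 (1.04 log units; beyond the scatter).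

Compound 4, `CCC(F)(F)C(=O)N1CCC(Oc2ncnc(Oc3ccc(S(C)(=O)=O)nc3C)c2F)CC1`, is not yet measured. It departs from compound 2 by one change on the carbonyl carbon:
1,1-difluoropropyl in place of (oxetan-3-yl)oxy on a carbonyl carbon

Among the measured compounds shown here, two measured steps bear on this change. The step from compound 2 to compound 1 shows that exchanging one oxygen-linked group for another already moves the number, and the step from compound 2 to compound 3, where the oxygen link itself is given up, is large. Compound 4 also gives up the oxygen link, so a lower number than that of compound 2 is expected, of a size between those two steps: an expected 8.2-fold lower number from compound 2 to compound 4 (0.91 log units; beyond the scatter). For compound 4 the estimate in this assay is 40 nM, with a range from 12 nM to 130 nM.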

Compound 4, half-maximal effective concentration: 17.4 nM
Compound 4: the middle estimate sits 2.3-fold (0.36 log units) above what was measured, within the range that was stated.
By their numbers in this assay, from the lowest: compound 3; then compound 4; then compound 1; then compound 2.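

In this assay, the carbonyl carbon no longer needs an oxygen or sulfur link to the group it carries: the carbon-linked 1,1-difluoropropyl group gives a 19-fold lower number from compound 2 to compound 4 (1.27 log units; beyond the scatter), even though it has no ring and no hydrogen-bond acceptors where the (oxetan-3-yl)oxy group has one ring and two acceptors, with the heavy-atom count unchanged. The gain is not confined to the comparison with the weakest compound in the set, as the other oxygen-linked group also gives way, with a 5.3-fold lower number from compound 1 to compound 4 (0.73 log units; beyond the scatter). The sulfur-linked group of compound 3 still gives the lowest number, with a 2.0-fold higher number from compound 3 to compound 4 (0.31 log units; beyond the scatter), so the new group recovers most of the ground between the oxetane compound and compound 3 but does not fully match it.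

No measurement shown here accounts for these differences between the groups. On these data alone, it remains open how a plain propyl chain without the two fluorine atoms, or a cyclobutyl group joined directly to the carbonyl carbon, would compare with compound 4 in this assay.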